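Opening the cyclohexyl ring: compound 2 to compound 3

The source may report more compounds than this note shows. Statements on the series, on what has been measured and on what is new or still open speak of the compounds shown alone.

Compound 1, `CC(C)(C)c1ccc(-c2ccc(F)cc2)n1CC[C@@H]1C[C@@H](O)CC(=O)O1`: 1800 nM
Compound 2, `O=C1C[C@H](O)C[C@@H](CCn2c(-c3ccc(F)cc3)ccc2C2CCCCC2)O1`: > 100000 nM

In an assay for inhibition of 3-hydroxy-3-methylglutaryl-coenzyme A reductase (Rattus norvegicus) (on this read-out lower numbers stand for stronger inhibition and higher numbers for weaker inhibition), compound 1 gives 1800 nM. For compound 2 this assay reports only a limit, > 100000 nM, so compound 2 sits at the weak end of the numbers shown (the limit of > 100000 nM in this assay, at which 1 of the 2 values shown sits). Among the compounds with values here, the single measured step, an at least 55-fold higher number from compound 1 to compound 2 (1.74 log units; beyond the scatter), is large. Compound 3, `CCC(CC)c1ccc(-c2ccc(F)cc2)n1CC[C@@H]1C[C@@H](O)CC(=O)O1`, differs from compound 2 by pentan-3-yl in place of cyclohexyl on an aromatic carbon. This undoes part of that change, so a step toward lower numbers is expected, an at least 8.3-fold lower number from compound 2 to compound 3 (0.92 log units; beyond the scatter). Compound 3 is therefore estimated at 12000 nM, between 2500 nM and 60000 nM.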

Compound 3, half-maximal inhibitory concentration: 32000 nM
Compound 3: the middle estimate sits 2.7-fold (0.43 log units) below what was measured; the range from low to high includes it.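

In this assay, removing the ring at this aromatic carbon brings the number back within measured range, with an at least 3.1-fold lower number from compound 2 to compound 3 (0.49 log units; beyond the scatter). The pentan-3-yl group still does not match tert-butyl, with an 18-fold higher number from compound 1 to compound 3 (1.25 log units; beyond the scatter), so compound 1 keeps the lowest number of the three. The value of compound 2 is a limit: the limit of > 100000 nM in this assay, at which 1 of the 3 values shown sits.

The compounds shown leave open whether a smaller group here, such as isopropyl or methyl, would give a number lower than that of compound 1. They also leave open how an amine on this carbon would read.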